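The compounds below may be only part of what the source reports. "The series", "measured", "known", "first", "only" and "open" are said of these compounds alone.

In a functional assay on MDA-MB-231 cells (Homo sapiens) for antiproliferative activity, read by MTT assay, with a stated time of 48 h (a higher number here means a weaker inhibitor, a lower number a stronger inhibitor), compound 1 (`C=CS(=O)(=O)N1CCN(c2ncnc3sc(-c4ccccc4)cc23)CC1`) gives 54200 nM and compound 2 (`CN1CCN(c2ccc(-c3cc4c(N5CCN(S(=O)(=O)C6CC6)CC5)ncnc4s3)cc2)CC1`) gives 11500 nM as the lower of the two numbers, a gap beyond the scatter. Compound 3 (`CN1CCN(c2ccc(-c3cc4c(N5CCN(C(=O)Nc6ccc(C#N)cc6)CC5)ncnc4s3)cc2)CC1`) differs from compound 2 in one place, with (4-cyanophenyl)carbamoyl in place of cyclopropylsulfonyl on an amine nitrogen in a ring. Among the compounds with values here, no measured pair shows this kind of change, so only a moderate move towards a lower number in this assay is expected, and the estimated step is a 1.9-fold lower number from compound 2 to compound 3 (0.28 log units; within the scatter) at its middle. The estimated value for compound 3 is 6000 nM (expected range 1500 nM to 25000 nM).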

Compound 3, half-maximal inhibitory concentration: 3930 nM
Compound 3: middle estimate off by 1.5-fold (0.18 log units), on the high side, and the stated range covers the measured number.
By their numbers in this assay, from the lowest: compound 3; then compound 2; then compound 1.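

At this amine nitrogen in a ring, (4-cyanophenyl)carbamoyl in place of cyclopropylsulfonyl gives a 2.9-fold lower number from compound 2 to compound 3 (0.47 log units; beyond the scatter) in this assay and shows that the position accepts a larger group carrying an aromatic ring and a hydrogen-bond donor. Within the data shown here, this is the first step that changes one place only. Nothing available explains the step. The compounds shown leave open whether the nitrile contributes, since a plain phenylcarbamoyl or an ethylcarbamoyl group on the same nitrogen does not appear among them.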